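From Methyl to Methyl Ester on a Well-Tolerated Compound

The compounds below may be only part of what the source reports. "The series", "measured", "known", "first", "only" and "open" are said of these compounds alone.

In an ADME assay on MT4 cells (Homo sapiens) for cytotoxicity (a higher number here means that more compound is tolerated, a lower number that less compound is tolerated), compound 1 `Cc1cc(C)cc(S(=O)(=O)n2c(SCC(=O)Nc3ccccc3Cl)nc3ccc(Cl)cc32)c1` gives 99300 nM. Compound 2 `Cc1cc(C)cc(S(=O)(=O)n2c(SCC(=O)Nc3ccc(C)cc3Cl)nc3ccc(Cl)cc32)c1` reads > 234000 nM, which is a limit and not a number. Compound 2 therefore stands at the limit of > 234000 nM in this assay, at which 1 of the 2 values shown sits.

Compound 3 `COC(=O)c1ccc(NC(=O)CSc2nc3ccc(Cl)cc3n2S(=O)(=O)c2cc(C)cc(C)c2)c(Cl)c1` has methoxycarbonyl in place of methyl on an aromatic carbon. Going by the values given here, one measured step bears on this carbon, with methyl in place of hydrogen: an at least 2.3-fold higher number from compound 1 to compound 2 (0.37 log units; beyond the scatter). That is only a loose guide, since a different group now enters. With the methyl gone, a modest move back toward compound 1 at 99300 nM is expected. The result for compound 3 could still reach the limit seen for compound 2. The expected step is an at least 2.1-fold lower number from compound 2 to compound 3 (0.32 log units; beyond the scatter). For compound 3, the estimate is 110000 nM, with an expected range from 40000 nM to 300000 nM.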

Compound 3, half-maximal cytotoxic concentration: >= 130000 nM
Compound 3 was reported as a limit; the forecaster's own chance of this, stated with the estimate: 35%; middle value at least 1.1-fold (0.07 log units) away from the limit.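

In this assay compound 3 reads >= 130000 nM, which is a limit and not a number. Set against hydrogen on this carbon, methoxycarbonyl gives an at least 1.3-fold higher number from compound 1 to compound 3 (0.11 log units; that floor lies within the scatter), so this larger group, with its four heavy atoms and two hydrogen-bond acceptors, brings no sign of lower tolerance, although that floor alone does not set compound 3 clearly apart from compound 1. Compound 2 and compound 3 both stand at limits and the step between them cannot be read, so methyl and methoxycarbonyl remain unranked on this carbon.

As far as these compounds go, the true values of compound 2 and compound 3 stay open, since each is known only as a limit. Also open, from the compounds shown here alone, is how a carboxylic acid or an amine on this carbon would read in this assay.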